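The source may report more compounds than this note shows. Statements on the series, on what has been measured and on what is new or still open speak of the compounds shown alone.

Measured compounds in a functional assay on CHO cells with adenosine receptor A1 (Homo sapiens) as the target, read by cAMP accumulation and immunoassay, with a stated time of 6 min, tested at 1 uM; on this read-out higher numbers stand for a weaker effect at the one concentration tested and lower numbers for a stronger effect:
compound 1 `Nc1scc(CN2CCN(c3cccc(C(F)(F)F)c3)CC2)c1C(=O)c1ccc(Cl)cc1` gives -72%
compound 2 `Nc1scc(CN2CCN(c3ccccc3C(F)(F)F)CC2)c1C(=O)c1ccc(Cl)cc1` gives -39%
compound 3 `Nc1scc(CN2CCN(c3cc(F)cc(F)c3)CC2)c1C(=O)c1ccc(Cl)cc1` gives -66%

Compound 2 stands highest of the three, with compound 3 nearest and compound 1 furthest, both steps beyond the scatter. Compound 4 `Nc1scc(CN2CCN(c3ccc(Cl)c(Cl)c3)CC2)c1C(=O)c1ccc(Cl)cc1` differs from compound 2 by 3,4-dichlorophenyl in place of 2-(trifluoromethyl)phenyl on an amine nitrogen in a ring. Within the data shown here, the steps that bear on this change are a number 27 percentage points lower from compound 2 to compound 3 (beyond the scatter) and a number 33 percentage points higher from compound 1 to compound 2 (beyond the scatter); both show that leaving the 2-(trifluoromethyl)phenyl for a ring substituted elsewhere brings a lower number beyond the scatter. Going by these compounds, the entering 3,4-dichlorophenyl is not among the measured compounds, so its exact position within the range of compound 1 and compound 3 is unknown. A step downward beyond the scatter is expected, estimated as a number 26 percentage points lower from compound 2 to compound 4 (beyond the scatter). Compound 4 is therefore expected to give about -65%, with a range from -85% to -42%.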

Compound 4, a percentage reported as activity, at one concentration (the size of the read-out at that concentration, not a potency): -60%
Compound 4: middle estimate off by 5 percentage points, on the low side; measured number inside the range.
By their numbers in this assay, from the lowest: compounds 1, 3 and 4 (each within the scatter of the next, the first and the last beyond it); then compound 2.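

In this assay the 3,4-dichlorophenyl group also gives a lower number than the 2-(trifluoromethyl)phenyl group on the amine nitrogen (a number 21 percentage points lower from compound 2 to compound 4 (beyond the scatter)), which extends this shift to a third replacement group. Compared with 3,5-difluorophenyl, it cannot be told apart (a number 6 percentage points higher from compound 3 to compound 4 (within the scatter)). Compared with 3-(trifluoromethyl)phenyl, it gives the first separation among the three replacement groups (a number 12 percentage points higher from compound 1 to compound 4 (beyond the scatter)).

Going by these compounds, how a pyridine ring in place of the phenyl, or a carboxylic acid on the phenyl, would read remains open. No available evidence explains these steps.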